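Lengthening a Butyl Chain on a Weak Activator

The source may report more compounds than this note shows. Statements on the series, on what has been measured and on what is new or still open speak of the compounds shown alone.

Of the compounds shown here, three have been measured in an assay on CHO cells for activation of soluble guanylate cyclase alpha1/beta1 complex (Homo sapiens), read by cGMP accumulation; a lower number here means that less compound is needed, a higher number that more compound is needed for the effect. Compound 1 `Nc1nc(-n2nc(Cc3ccccc3F)c3ccccc32)nc2c1CC(=O)N2` gives 160 nM, and compound 3 `COC(=O)N(C)c1c(N)nc(-n2nc(Cc3ccccc3F)c3ccccc32)nc1N` gives 310 nM. Compound 2 `CCCCc1nn(-c2nc(N)c3c(n2)NC(=O)C3(C)C)c2ccc(Cl)cc12` stands apart from both: in this assay compound 2 gives 47000 nM, the highest of the three numbers, meaning far more of it is needed. The gap to compound 3, its nearest neighbour, is large and well beyond the usual scatter, and the gap to compound 1 is larger still. Compound 2 also has a different core from the other two, so none of the three pairs differs in just one place, and no single step can be read from them.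

Compound 4 `CCCCCc1nn(-c2nc(N)c3c(n2)NC(=O)C3(C)C)c2ccc(Cl)cc12` is built from compound 2 with one change: methyl in place of hydrogen on a saturated chain carbon, four bonds along the chain from an aromatic carbon. Read one bond further out, this is a butyl chain becoming a pentyl chain. For the measured compounds named here, no measured pair shows what such a change does here. Since only one carbon is added at the end of a chain, the step from compound 2 to compound 4 is expected to stay within the scatter, with no clear direction: a 1.2-fold lower number from compound 2 to compound 4 (0.07 log units; within the scatter). Compound 4 is therefore estimated at 40000 nM, with a likely range from 15000 nM to 120000 nM.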

Compound 4, half-maximal effective concentration: 90000 nM
Estimate against measurement, compound 4: 2.3-fold (0.35 log units) below; the measured number falls inside the stated range.
By their numbers in this assay, from the lowest: compounds 1 and 3 (each within the scatter of the next); then compounds 2 and 4 (each within the scatter of the next).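

In this assay, methyl in place of hydrogen on a saturated chain carbon, four bonds along the chain from an aromatic carbon, gives a 1.9-fold higher number from compound 2 to compound 4 (0.28 log units; within the scatter), so the numbers for this pair cannot be told apart from repeated measurement. For the compounds shown here, this is the first direct reading at this position, as the earlier compounds offered no pair differing in one place: extending the butyl chain to a pentyl chain by this single carbon has no effect that this assay can resolve. The data on hand offer no explanation for this result, and a single step gives no trend along the chain.

Still open, as far as these compounds go, is whether a longer chain, such as a hexyl chain, or a shorter propyl chain would move the number beyond the scatter, or whether an amine or a carboxylic acid at the end of the chain would do so. Also open, from the compounds shown here alone, is whether the same added carbon would behave in the same way on a different core, such as that of compound 1, which carries no comparable chain.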